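The compounds below may be only part of what the source reports. "The series", "measured", "known", "first", "only" and "open" are said of these compounds alone.

Of the compounds shown here, three have so far been measured in an assay on isolated protein for inhibition of histone deacetylase 8 (Homo sapiens); on this read-out lower numbers stand for stronger inhibition and higher numbers for weaker inhibition. Compound 1 `Cc1ccc(C(=O)c2ccc3c(ccn3Cc3ccc(C(=O)NO)cc3)c2)cc1` gives 1490 nM, compound 3 `COc1cccc(C(=O)c2ccc3c(ccn3Cc3ccc(C(=O)NO)cc3)c2)c1` gives 1120 nM, and compound 2 `COc1ccc(C(=O)c2ccc3c(ccn3S(=O)(=O)c3cccc(/C=C/C(=O)NO)c3)c2)cc1OC` gives 1420 nM. The three numbers sit close together: the step of a 1.3-fold lower number from compound 1 to compound 3 (0.12 log units; within the scatter) stays within the scatter, and compound 2 gives the second highest of the three numbers, yet its gaps to compound 1 and to compound 3 are both within the scatter.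

Compound 4 `O=C(/C=C/c1cccc(S(=O)(=O)n2ccc3cc(C(=O)c4ccc(F)cc4)ccc32)c1)NO` has not yet been measured. It differs from compound 2 in one place: 4-fluorophenyl in place of 3,4-dimethoxyphenyl on a carbonyl carbon. Among the compounds with values here, the only measured step that touches the same kind of position is a 1.3-fold lower number from compound 1 to compound 3 (0.12 log units; within the scatter), in a pair whose remaining structure differs from compound 2, and it changed nothing beyond the scatter. Within the data shown here, no measured pair shows the effect of losing the two methoxy groups or of gaining fluorine. On that basis the expected change a 1.0-fold lower number from compound 2 to compound 4 (0.01 log units; within the scatter) is none beyond the scatter. For compound 4 the estimate in this assay is 1400 nM, with a range from 500 nM to 4000 nM.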

Compound 4, half-maximal inhibitory concentration: 2750 nM
The estimate for compound 4 lay 2.0-fold (0.29 log units) below the measured number; low and high end bracket the measured number.
By their numbers in this assay, from the lowest: compounds 3, 2, 1 and 4 (each within the scatter of the next, the first and the last beyond it).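

In this assay, putting 4-fluorophenyl in place of 3,4-dimethoxyphenyl on a carbonyl carbon gives a 1.9-fold higher number from compound 2 to compound 4 (0.29 log units; within the scatter) and so counts as no clear change, even though the group goes from 10 heavy atoms to 7 and from 2 hydrogen-bond acceptors to 0. This gives a direct reading of the position on the core of compound 2, and, with the step on the core of compound 1, neither change measured at this position lies beyond the scatter. No measurement shown explains the size of this step.

Going by these compounds, every group on this carbonyl carbon so far is a substituted phenyl ring, so the effect of an amine or a carboxylic acid on that ring remains open. Also open, on these data alone, is what a longer alkyl chain in place of the ring would do.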